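Ring exchange on the shared core of the series

A few compounds are considered here, and "the series" means these few. Any claim that something is new, unique, unknown or untested is made for them only; others in the source may bear on it.

Within the data shown here, two measured compounds define the series so far. Compound 1 `O=C(NCCCCc1ccccc1)n1c(=O)oc2cc(C3CCOCC3)ccc21` carries an oxan-4-yl group on its core; in an assay on HEK293 cells for inhibition of acid ceramidase (Homo sapiens), read by fluorescence, with stated times of 10 min and 3 h (a higher number here means a weaker inhibitor, a lower number a stronger inhibitor), compound 1 gives 68 nM, the lowest of the two numbers. Compound 2 `CCOCCNC(=O)n1c(=O)oc2cc(-c3ccc(F)cc3)ccc21` is the only other point: in this assay compound 2 gives 2300 nM, a weaker result than compound 1 by a gap beyond the scatter. Compound 3 `CCN1CCC(c2ccc3c(c2)oc(=O)n3C(=O)NCCCCc2ccccc2)CC1` is not yet measured. It differs from compound 1 at one site: 1-ethylpiperidin-4-yl in place of oxan-4-yl on an aromatic carbon. Both groups bring one six-membered non-aromatic ring with one hetero atom and one hydrogen-bond acceptor. Among the measured compounds shown here, no measured pair shows this exchange, and compound 2 differs from compound 1 in more than one place, so it offers no guide. The expected step in this assay is small, within the scatter or slightly toward a higher number, as a 1.3-fold higher number from compound 1 to compound 3 (0.10 log units; within the scatter). Compound 3 is therefore estimated at 85 nM in this assay, with a range of 25 nM to 300 nM.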

Compound 3, half-maximal inhibitory concentration: 92 nM
Estimate against measurement, compound 3: 1.1-fold (0.03 log units) below; the measured number falls inside the stated range.
By their numbers in this assay, from the lowest: compounds 1 and 3 (each within the scatter of the next); then compound 2.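

In this assay, among these compounds, the series now has its only single-site step: 1-ethylpiperidin-4-yl in place of oxan-4-yl on an aromatic carbon gives a 1.4-fold higher number from compound 1 to compound 3 (0.13 log units; within the scatter), so the two groups cannot be told apart here. At this position, with the rest of compound 1 held fixed, a ring nitrogen bearing an ethyl group can stand in for the ring oxygen, and a group of 8 heavy atoms for one of 6, without a change beyond the scatter. Nothing measured explains this result, and no separate data on either group bear on it.

Still open, as far as these compounds go, is whether this holds for groups other than six-membered non-aromatic rings, such as a phenyl ring, a carboxylic acid or a piperidine with no ethyl on its nitrogen. Among the compounds shown here, also open is whether the same exchange gives a similar step with a shorter chain in place of the one shared by compound 1 and compound 3.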